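Chain change from compound 2 to compound 4

This account rests on a few compounds, and the source may have more. Where it says the series, first, only, none or still open, it means among the compounds named here.

In a functional assay on A-375 cells (Homo sapiens), read by thymidine incorporation (on this read-out higher numbers stand for weaker inhibition and lower numbers for stronger inhibition), compound 1 `CC(=O)N[C@H]1[C@@H](OCc2ccccc2)O[C@H](CO)[C@@H](O)[C@@H]1O` gives only a limit, > 50 uM. For the measured compounds named here, compound 2 `CCCCCCCCCCCCCCCCO[C@H]1O[C@H](CO)[C@@H](O)[C@H](O)[C@H]1NC(C)=O` gives 29.3 uM, the only actual number returned so far in this assay. Compound 3 `C=CCCC(=O)N[C@H]1[C@@H](OCCCCCCCCCCCCCCCC)O[C@H](CO)[C@@H](O)[C@@H]1O` again gives only a limit, > 50 uM. Going by the values given here, the single measured step, an at least 1.7-fold higher number from compound 2 to compound 3 (0.23 log units; that floor lies within the scatter), concerns allyl in place of hydrogen on a saturated chain carbon bound to a carbonyl carbon; its floor lies within the scatter, and it touches the amide side of the core, not the chain on the oxygen on a saturated carbon.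

Compound 4 `CCCCCCCC/C=C\CCCCCCCCO[C@H]1O[C@H](CO)[C@@H](O)[C@H](O)[C@H]1NC(C)=O` differs from compound 2 by dec-1-en-1-yl in place of octyl on a saturated chain carbon, eight bonds along the chain from an oxygen on a saturated carbon. Among the compounds with values here, no measured step alters this chain, so the steps so far give no direct guidance on the size or direction of the change. The one thing that bears on the outcome is the limit of > 50 uM in this assay, at which 2 of the 3 values shown sit, which makes a limit rather than a number a real possibility for any new member. For this change no step beyond the scatter is expected in either direction. Compound 4 is therefore expected to come out near 25 uM, within 10 uM to 60 uM, corresponding to an expected step of a 1.2-fold lower number from compound 2 to compound 4 (0.07 log units; within the scatter).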

Compound 4, concentration for 50% inhibition: 4.8 uM
For compound 4 the middle estimate is 5.2-fold (0.72 log units) above the measured one; measured number outside the range, below it.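

The chain on the oxygen on a saturated carbon is a responsive position in this assay: dec-1-en-1-yl in place of octyl, eight bonds along the chain from an oxygen on a saturated carbon, gives a 6.1-fold lower number from compound 2 to compound 4 (0.79 log units; beyond the scatter). For the compounds shown here, this is the first step that is read as beyond the scatter, whereas the only earlier one, an at least 1.7-fold higher number from compound 2 to compound 3 (0.23 log units; that floor lies within the scatter), has a floor within the scatter and lies on the amide side of the core. Compound 4 also returns an actual number, which gives the series a second measured point in an assay where limits are common: the limit of > 50 uM in this assay, at which 2 of the 4 values shown sit.

The change brings in a longer chain and a double bond together, so the compounds shown cannot separate the two contributions; a fully saturated chain of the same length as in compound 4, or the same double bond on a chain of the length in compound 2, would do so. Also open, as far as these compounds go, are the trans double bond, a chain ending in a carboxylic acid or an amine, and whether the amide change of compound 3 behaves the same way on the chain of compound 4.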